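This account rests on a few compounds, and the source may have more. Where it says the series, first, only, none or still open, it means among the compounds named here.

Compound 1 `CCC/N=C1\S/C(=C\c2ccc(O)c(Cl)c2)C(=O)N1C1CCN(C)C(=O)C1` in a physicochemical assay for solubility, measured as kinetic solubility; on this read-out lower numbers stand for lower solubility and higher numbers for higher solubility: the limit > 250000 nM.
Compound 2 `Cc1ccccc1N1C(=O)/C(=C/c2ccc(O)c(Cl)c2)S/C1=N\C1COC1` in this assay: 150000 nM.
Compound 3 `CCC/N=C1\S/C(=C\c2ccc(O)c(Cl)c2)C(=O)N1C1CC1` in this assay: 79000 nM.

Compound 1 stands at the top of these numbers, yet its entry is only a limit of this assay, not a measured number (the limit of > 250000 nM in this assay, at which 1 of the 3 values shown sits). Compound 4 `CCC/N=C1\S/C(=C\c2ccc(O)c(Cl)c2)C(=O)N1c1ccccc1C` differs from compound 1 in one place (2-methylphenyl in place of 1-methyl-2-oxopiperidin-4-yl on an amide-type nitrogen in a ring). For the measured compounds named here, the one measured step at this position is an at least 3.1-fold lower number from compound 1 to compound 3 (0.50 log units; beyond the scatter). Compound 2 also carries 2-methylphenyl on an amide-type nitrogen in a ring and gives 150000 nM in this assay. Compound 4 is therefore expected to move downward, by about an at least 4.1-fold lower number from compound 1 to compound 4 (0.61 log units; beyond the scatter). For compound 4 the estimate in this assay is 60000 nM, within a range of 20000 nM to 200000 nM.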

Compound 4, solubility: 79000 nM
For compound 4 the middle estimate is 1.3-fold (0.12 log units) below the measured one, and the stated range covers the measured number.
By their numbers in this assay, from the lowest: compounds 3, 4 and 2 (each within the scatter of the next). At a limit, above all of these: compound 1.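

In this assay, 2-methylphenyl on the amide-type nitrogen in a ring falls with cyclopropyl rather than with 1-methyl-2-oxopiperidin-4-yl: the two carbon-only groups give no change at the digits printed from compound 3 to compound 4 (within the scatter), while leaving the oxopiperidine gives an at least 3.1-fold lower number from compound 1 to compound 4 (0.50 log units; beyond the scatter). With 2-methylphenyl kept, propyl in place of oxetan-3-yl on a double-bonded nitrogen gives a 1.9-fold lower number from compound 2 to compound 4 (0.28 log units; within the scatter). From the compounds shown here alone, how far compound 1 truly sits from the others stays open, as its entry is only a limit: the limit of > 250000 nM in this assay, at which 1 of the 4 values shown sits. Also open, going by these compounds, is how an amine or a carboxylic acid at this position would read.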